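Sulfonyl aryl swap on the enone series

The source may report more compounds than this note shows. Statements on the series, on what has been measured and on what is new or still open speak of the compounds shown alone.

Among the compounds with values here, the three measured members share one core. Compound 1 `O=C(Nc1cccc(/C=C/C(=O)c2nc3ccccc3[nH]2)c1)c1ccccc1` gives 8340 nM in a functional assay on 143B cells (Homo sapiens) for antiproliferative activity, read by MTT assay, with a stated time of 48 h; on this read-out lower numbers stand for stronger inhibition and higher numbers for weaker inhibition. Compound 2 `O=C(Nc1cccc(/C=C/C(=O)c2nc3ccccc3[nH]2)c1)c1cccc(Cl)c1` gives 3370 nM in this assay, and compound 3 `O=C(/C=C/c1cccc(NS(=O)(=O)c2ccc(Cl)cc2)c1)c1nc2ccccc2[nH]1` gives 7450 nM in this assay. Compound 3 thus stands second highest of the three numbers: its gap to compound 1 lies within the scatter, whereas a 2.2-fold higher number from compound 2 to compound 3 (0.34 log units; beyond the scatter) lies beyond it. The steps of a 2.5-fold lower number from compound 1 to compound 2 (0.39 log units; beyond the scatter) and a 1.1-fold lower number from compound 1 to compound 3 (0.05 log units; within the scatter) complete what has been seen so far.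

Compound 4 `Cc1cc(C)cc(S(=O)(=O)Nc2cccc(/C=C/C(=O)c3nc4ccccc4[nH]3)c2)c1` differs from compound 3 in one place: 3,5-dimethylphenyl in place of 4-chlorophenyl on a sulfonyl sulfur. Within the data shown here, no measured step touches the aryl group on the sulfonyl sulfur. Among the measured compounds shown here, the only measured change on an aryl ring, a 2.5-fold lower number from compound 1 to compound 2 (0.39 log units; beyond the scatter), sits on the benzoyl group and is modest, and the two swaps of sulfonyl for carbonyl on the ring nitrogen were modest or within the scatter. Nothing here separates a chloro from two methyl groups on that ring. The step expected in this assay is therefore a 1.1-fold lower number from compound 3 to compound 4 (0.03 log units; within the scatter), small and of uncertain direction. Compound 4 is expected to give 7000 nM, with a range from 3000 nM to 16000 nM.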

Compound 4, half-maximal inhibitory concentration: 3330 nM
Compound 4: the middle estimate sits 2.1-fold (0.32 log units) above what was measured; the measured number falls inside the stated range.
By their numbers in this assay, from the lowest: compounds 4 and 2 (each within the scatter of the next); then compounds 3 and 1 (each within the scatter of the next).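

Within the data shown here, the aryl group on the sulfonyl sulfur is not silent in this assay and gives a 2.2-fold lower number from compound 3 to compound 4 (0.35 log units; beyond the scatter) as the first measured step at this place, modest in size but beyond the scatter. Both groups in this change are a single six-membered aromatic ring of carbon only, with no hydrogen-bond donors, no hydrogen-bond acceptors and no net charge, so the computed description separates them only by their atoms: 4-chlorophenyl has 7 heavy atoms including a chlorine, and 3,5-dimethylphenyl has 8, all carbon. No supporting data bear on why the number moves at this position.

The step combines losing the chloro group with gaining two methyl groups, so this single pair cannot assign it to either part of the swap or to the substitution pattern on the ring. On these data alone, how a plain phenyl ring, or an aryl ring carrying an amine or a carboxylic acid, would read on the sulfonyl sulfur in this assay remains open.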